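A Nitrile Replaces a Phenol on the Shared Core

The source may hold more compounds than are shown below. What is called first, only, known or untested is meant among the compounds shown, and "the series" means these compounds.

Measured compounds:
compound 1 `Cc1cc(-c2ccc3ccc(C(=O)c4ccc(F)c(O)c4)nc3c2)ccc1O`: 80%
compound 2 `CN(c1ccc(F)c(O)c1)c1cccc(-c2cccc(O)c2F)n1`: 100%

Both were tested in an assay for inhibition of 17-beta-hydroxysteroid dehydrogenase type 2 (Homo sapiens), read by HPLC, with a stated time of 10 min, tested at 1 uM; on this read-out lower numbers stand for less inhibition and higher numbers for more inhibition at the one concentration tested (going by the name of the read-out). Among these two numbers compound 1 stands lowest, and compound 2 lies higher by a margin beyond the usual scatter. Compound 3 `N#Cc1ccc2ccc(C(=O)c3ccc(F)c(O)c3)nc2c1` has not been measured yet. It differs from compound 1 in one place: cyano in place of 4-hydroxy-3-methylphenyl on an aromatic carbon. Within the data shown here, a small cyano group thus takes the spot of a much larger ring-bearing group, and no measured pair shows such a swap. Inhibition is expected to fall beyond the scatter, a step of a number 30 percentage points lower from compound 1 to compound 3 (beyond the scatter). Compound 3 is therefore estimated at 50%, within 20% to 80%.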

Compound 3, a percentage reported as inhibition, at one concentration (the size of the read-out at that concentration, not a potency): 56%
Estimate against measurement, compound 3: 6 percentage points below; the range from low to high includes it.
By their numbers in this assay, from the lowest: compound 3; then compound 1; then compound 2.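

In this assay putting cyano in place of 4-hydroxy-3-methylphenyl on this aromatic carbon gives a number 24 percentage points lower from compound 1 to compound 3 (beyond the scatter) and so shows that the number responds to a change at this position. Even without that ring, compound 3 gives 56% at the one concentration tested, so inhibition does not vanish with its loss. Nothing measured here explains the fall. The compounds shown leave open whether the fall follows the loss of the ring or of its hydroxy group, which a plain phenyl ring at this position would help separate. From the compounds shown here alone, how an amine or a carboxylic acid would fare there also remains open.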